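Swapping bromo for hydrogen at the limit of tolerance

The source may report more compounds than this note shows. Statements on the series, on what has been measured and on what is new or still open speak of the compounds shown alone.

In an ADME assay on MT4 cells (Homo sapiens) for cytotoxicity, read by MTT assay, with a stated time of 96 h (a higher number here means that more compound is tolerated, a lower number that less compound is tolerated), compound 1 `FC(F)(F)c1ccc(NCc2cn(-c3ccccc3)nc2-c2ccc(Br)cc2)cc1` gives > 100000 nM as a limit and not a number. Compound 2 `Cc1ccc(NCc2cn(-c3ccccc3)nc2-c2ccc(C)cc2)cc1` gives > 100000 nM as a limit too. Compound 3 `Cc1ccc(-c2nn(-c3ccccc3)cc2CNc2ccc(Br)cc2)cc1` gives > 100000 nM as a limit too. Compound 1 thus stands with the other two, and the limit of > 100000 nM in this assay, at which 3 of the 3 values shown sit, is the whole picture so far. Moving to compound 4 `FC(F)(F)c1ccc(NCc2cn(-c3ccccc3)nc2-c2ccccc2)cc1` is hydrogen in place of bromo on an aromatic carbon with hydrogen in place of bromo on an aromatic carbon. Among the measured compounds shown here, the one measured step is a step that the two limits leave unreadable from compound 2 to compound 3 and it offers no size to go on. No step beyond the scatter is therefore expected in this assay here. The estimated a number no higher from compound 1 to compound 4 (the limit leaves the size open) is expected to show no real change. For compound 4 the estimate is 100000 nM with an expected range of 50000 nM to 200000 nM and the expected outcome may well be a limit.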

Compound 4, half-maximal cytotoxic concentration: > 100000 nM
Compound 4 gave a limit, no number; the forecaster's own chance of this, stated with the estimate: 85%; the middle value sits exactly at the limit.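

The step from compound 1 to compound 4 cannot be read, since both give only a limit and not a number: the limit of > 100000 nM in this assay, at which 4 of the 4 values shown sit.

The compounds shown leave open how much of any of them the cells would tolerate, and whether bromo or hydrogen makes any difference.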